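Triazolyl substituent on the shared core: expectation for compound 4

The source may hold more compounds than are shown below. What is called first, only, known or untested is meant among the compounds shown, and "the series" means these compounds.

Compound 1 `CNc1nc(NC2(C#N)CCCCC2)nc(-n2ccnc2)n1` and compound 2 `CNc1nc(NC2(C#N)CCCCC2)nc(OC)n1` are the two members of the series with a number in an in vitro assay on Sf21 cells for inhibition of high affinity 3',5'-cyclic-AMP phosphodiesterase 7A (Homo sapiens); on this read-out lower numbers stand for stronger inhibition and higher numbers for weaker inhibition. In this assay compound 1 gives 1050 nM, and compound 2 gives 521 nM. Within the data shown here, the only single-point step between them, a 2.0-fold lower number from compound 1 to compound 2 (0.30 log units; within the scatter), shows that exchanging the five-membered ring for a methoxy group at that position leaves the read-out unchanged within the noise. Compound 3 `CNc1nc(N)nc(NC2(C#N)CCCCC2)n1` carries an amino group at the same position; in this assay compound 3 gives "not determined" (no result reported), so it stands nowhere on the numbers and cannot serve as an anchor.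

Compound 4 `CNc1nc(NC2(C#N)CCCCC2)nc(-n2cnc(C)n2)n1` differs from compound 3 by 3-methyl-1H-1,2,4-triazol-1-yl in place of amino on an aromatic carbon. Among the measured compounds shown here, no measured step covers this exact exchange. What bears on it is that the ring entering in compound 4 is closest to the ring present in compound 1, and that the step from compound 1 to compound 2 was small, so this position seems to accept both a ring and a small group without a shift beyond the scatter. The expectation is therefore a number near that of compound 1, with no clear direction.

Compound 4 is expected to give 1000 nM in this assay, with a range from 300 nM to 3500 nM.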

Compound 4, half-maximal inhibitory concentration: > 5000 nM
Compound 4: no number, only a limit; the forecaster's own chance of this, stated with the estimate: 10%; middle value at least 5.0-fold (0.69 log units) from the limit.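

In this assay compound 4 gives no number, only a limit: the limit of > 5000 nM in this assay, at which 1 of the 4 values shown sits.

Even so, the position opposite the ring nitrogen proves sensitive to the group it carries, with an at least 9.5-fold higher number from compound 2 to compound 4 (0.98 log units; beyond the scatter) and an at least 4.7-fold higher number from compound 1 to compound 4 (0.67 log units; beyond the scatter). The earlier 2.0-fold lower number from compound 1 to compound 2 (0.30 log units; within the scatter) gave no sign of this, and the new steps show that a five-membered aromatic ring at this place does not guarantee a read-out like that of 1H-imidazol-1-yl, since 3-methyl-1H-1,2,4-triazol-1-yl falls beyond the scatter from it.

As far as these compounds go, it remains open whether the weaker inhibition follows the methyl group or the triazole ring itself, a question that the unsubstituted 1H-1,2,4-triazol-1-yl group would address at this position. Also open, from the compounds shown here alone, are how far the true value of compound 4 lies beyond its limit and how an open-chain group such as dimethylamino or ethoxy would read here, given that compound 3, with its amino group, offers no number for comparison.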